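Replacing the larger group of compound 2 with pyridin-3-yl

The compounds below may be only part of what the source reports. "The series", "measured", "known", "first", "only" and "open" are said of these compounds alone.

Measured in a functional assay for inhibition, with Homo sapiens as the target (a higher number here means a weaker inhibitor, a lower number a stronger inhibitor), so far:
Compound 1 `CCCC(Oc1ccc2c(c1)c(SC(C)(C)C)c(CC(C)(C)C(=O)O)n2Cc1ccc(Cl)cc1)c1ccc2ccccc2n1` gives > 52 nM (a limit)
Compound 2 `CC(C)(C)Sc1c(CC(C)(C)C(=O)O)n(Cc2ccc(Cl)cc2)c2ccc(OCc3ccc4cnccc4n3)cc12` gives 3 nM
Compound 3 `CC(C)(C)Sc1c(CC(C)(C)C(=O)O)n(Cc2ccc(Cl)cc2)c2ccc(OCc3nc4cc(C(F)(F)F)ccc4s3)cc12` gives 22 nM

The value for compound 1 is a limit. Of the two actual numbers, compound 2 has the lower, and its gap to compound 3 lies beyond the scatter. Compound 4 `CC(C)(C)Sc1c(CC(C)(C)C(=O)O)n(Cc2ccc(Cl)cc2)c2ccc(OCc3cccnc3)cc12` has not yet been measured. Its difference from compound 2 is this: a group of 6 heavy atoms (5 carbon, 1 nitrogen; one six-membered aromatic ring with 1 hetero atom) in place of a group of 10 heavy atoms (8 carbon, 2 nitrogen; 2 six-membered aromatic rings with 1 hetero atom each), on a saturated chain carbon bound to an oxygen on an aromatic ring. For the measured compounds named here, no measured pair isolates this change. A higher number beyond the scatter is nevertheless expected, since compound 3 (22 nM) also carries a different group at this place and stands above compound 2 (3 nM). The expected step is a 10-fold higher number from compound 2 to compound 4 (1.00 log units; beyond the scatter) in this assay. For compound 4 the estimate is 30 nM (8 nM to 110 nM).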

Compound 4, half-maximal inhibitory concentration: 8 nM
Compound 4: the middle estimate sits 3.8-fold (0.57 log units) above what was measured, within the range that was stated.
By their numbers in this assay, from the lowest: compound 2; then compound 4; then compound 3. At a limit, above all of these: compound 1.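

For the compounds shown here, at this place, on a saturated chain carbon bound to an oxygen on an aromatic ring, this assay gives the first isolated reading of a change of group: a 2.7-fold higher number from compound 2 to compound 4 (0.43 log units; beyond the scatter). The loss is modest but beyond the scatter, so a single pyridin-3-yl ring retains much of the inhibition without the second six-membered aromatic ring. Nothing shown accounts for the size of this step. Open, as far as these compounds go, is whether a phenyl ring, carrying no ring nitrogen, would give a comparable number. Also open, from the compounds shown here alone, is how pyridin-2-yl or pyridin-4-yl would compare with pyridin-3-yl.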